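The source may report more compounds than this note shows. Statements on the series, on what has been measured and on what is new or still open speak of the compounds shown alone.

The shared core carries an aryl ether and, in compound 1 `Cc1oc(C(=O)O)cc1COc1ccc(-c2ccc(C#N)cc2)cc1`, a 4-cyanophenyl group; compound 1 gives 1500 nM in an assay on cells for displacement of a labelled ligand from prostaglandin E2 receptor EP4 subtype (Homo sapiens), read by scintillation counting; on this read-out higher numbers stand for weaker inhibition and lower numbers for stronger inhibition. Compound 2 `COc1ccc(-c2ccc(OCc3cc(C(=O)NS(=O)(=O)c4ccccc4)oc3C)cc2)nc1`, which carries an acylsulfonamide in place of the acid, gives 22 nM in this assay. Compound 3 `Cc1oc(C(=O)O)cc1COc1ccc(-c2ccoc2)cc1` reaches only a limit in this assay, > 10000 nM, and so sits at the weak end of the numbers shown, at the limit of > 10000 nM in this assay, at which 1 of the 3 values shown sits. For the measured compounds named here, the one measured step that bears on it is an at least 6.6-fold higher number from compound 1 to compound 3 (0.82 log units; beyond the scatter), where a five-membered aromatic ring replaced a six-membered one and the number rose. Compound 4 `COc1ccc(-c2ccc(OCc3cc(C(=O)O)oc3C)cc2)nc1` runs the other way: 5-methoxypyridin-2-yl in place of furan-3-yl on an aromatic carbon. A six-membered aromatic group returns in the place the step from compound 1 to compound 3 emptied, so a move to a lower number beyond the scatter is expected, roughly of the size seen there. The expected step is an at least 20-fold lower number from compound 3 to compound 4 (1.30 log units; beyond the scatter). Compound 4 is estimated to give 500 nM in this assay, within a range from 100 nM to 3000 nM.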

Compound 4, inhibition constant: 1300 nM
Compound 4: the middle estimate sits 2.6-fold (0.41 log units) below what was measured; the measured number falls inside the stated range.
By their numbers in this assay, from the lowest: compound 2; then compounds 4 and 1 (each within the scatter of the next). At a limit, above all of these: compound 3.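

With 5-methoxypyridin-2-yl on this aromatic carbon, para to a large group, the number comes back from the furan-3-yl level, and an at least 7.6-fold lower number from compound 3 to compound 4 (0.88 log units; beyond the scatter) gives only the least size of that step, since compound 3 stands at a limit: the limit of > 10000 nM in this assay, at which 1 of the 4 values shown sits. A ring nitrogen and a methoxy group are tolerated here, as a 1.2-fold lower number from compound 1 to compound 4 (0.06 log units; within the scatter) leaves 5-methoxypyridin-2-yl and 4-cyanophenyl indistinguishable in this assay. With 5-methoxypyridin-2-yl held constant, a 59-fold higher number from compound 2 to compound 4 (1.77 log units; beyond the scatter) shows that hydroxy in place of (phenylsulfonyl)amino on the carbonyl carbon separates the pair by a large margin.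

Whether the ring nitrogen or the methoxy group accounts for the recovery stays open, as a plain phenyl or a 4-methoxyphenyl group would be needed to separate them. Also open, as far as these compounds go, is whether a tetrazole in place of the carboxylic acid would give a similar shift.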